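Bromophenyl ether series: step from compound 3 to compound 4

A few compounds are considered here, and "the series" means these few. Any claim that something is new, unique, unknown or untested is made for them only; others in the source may bear on it.

Measured compounds:
compound 1 `CN(C)CCCOc1cccc(CN2CC[C@H](NC(=O)c3ccc(Cl)c(Cl)c3)C2)c1` — > 3000 nM
compound 2 `CN1CCC(Oc2ccc(CN3CCC(NC(=O)c4ccc(Cl)c(Cl)c4)C3)cc2Br)C1` — 41 nM
compound 3 `CN(C)CCCOc1ccc(CN2CC[C@H](NC(=O)c3ccc(Cl)c(Cl)c3)C2)cc1Br` — 61 nM

In an assay on HEK293 cells for displacement of a labelled ligand from Urotensin-2 receptor (Homo sapiens) (on this read-out lower numbers stand for stronger inhibition and higher numbers for weaker inhibition), compound 1 reaches only a limit of the assay and not a number, > 3000 nM. Compound 3, with 61 nM, is one of two compounds carrying a number; its nearest neighbour is compound 2 at 41 nM, and the gap between them lies within the scatter, so no order is read.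

Compound 4 `O=C(N[C@H]1CCN(Cc2ccc(O[C@H]3CCNC3)c(Br)c2)C1)c1ccc(Cl)c(Cl)c1` differs from compound 3 by pyrrolidin-3-yl in place of 3-(dimethylamino)propyl on an oxygen on an aromatic ring. Among the measured compounds shown here, no single-change step between measured compounds exists to size this move. The expected step is a 1.4-fold lower number from compound 3 to compound 4 (0.13 log units; within the scatter), none beyond the scatter, with compound 2 giving 41 nM as the nearest point of reference. For compound 4 the estimate in this assay is 45 nM, expected between 12 nM and 170 nM.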

Compound 4, inhibition constant: 44 nM
Estimate against measurement, compound 4: 1.0-fold (0.01 log units) above, within the range that was stated.
By their numbers in this assay, from the lowest: compounds 2, 4 and 3 (each within the scatter of the next). At a limit, above all of these: compound 1.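

In this assay, the group on this oxygen can pass from an open chain to a ring with no change that can be read: a 1.4-fold lower number from compound 3 to compound 4 (0.14 log units; within the scatter). The entering pyrrolidin-3-yl also brings a hydrogen-bond donor and a defined stereocentre that 3-(dimethylamino)propyl lacks, and the step still stays within the scatter. Nothing shown gives a reason for this result.

As far as these compounds go, what a carboxylic acid or a longer amine chain on this oxygen would give stays open. From the compounds shown here alone, compound 1 gives only a limit, > 3000 nM, and differs from compound 3 in more than one place, so the contribution of the bromine also stays open.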